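Swapping the Amide Cap of Compound 1

The source may hold more compounds than are shown below. What is called first, only, known or untested is meant among the compounds shown, and "the series" means these compounds.

Measured compounds:
compound 1 `O=C(CCCCCCNC(=O)C(O)(O)C(F)(F)F)Nc1nc2ccccc2s1` — 2370 nM
compound 2 `CCOc1ccc(-c2cnc(NC(=O)CCCCCCNC(=O)C(O)(O)C(F)(F)F)s2)cc1` — 4050 nM
compound 3 `O=C(CCCCNC(=O)c1cc(=O)c(O)co1)Nc1ccccc1` — > 100000 nM

All three were tested in a functional assay on HCT-116 cells (Homo sapiens) for inhibition, read by colorimetric assay, with a stated time of 3 days; a lower number here means a stronger inhibitor, a higher number a weaker inhibitor. Compound 1 gives 2370 nM and compound 2 gives 4050 nM; of the two numbers, that of compound 1 is the lower, but compound 2 lies within the usual scatter of it, so the two cannot be told apart. Compound 3 reaches only a limit of the assay, > 100000 nM, and this is where (the limit of > 100000 nM in this assay, at which 1 of the 3 values shown sits). No pair of these compounds differs in a single place, so no measured step is available to lean on.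

The compound still to be measured is compound 4 `CC(=O)c1ccc(NC(=O)CCCCCCNC(=O)C(O)(O)C(F)(F)F)cc1`. It differs from compound 1 in one place: 4-acetylphenyl in place of 1,3-benzothiazol-2-yl on an amide-type nitrogen. The chain and its fluorinated end are kept; only the cap on the amide nitrogen changes. Compound 3 carries a different chain end as well, so it does not isolate this change. The step from compound 1 to compound 4 is expected to be a modest loss, a 2.1-fold higher number from compound 1 to compound 4 (0.32 log units; beyond the scatter), somewhat beyond the scatter. In this assay compound 4 is therefore estimated at 5000 nM, within a range from 1500 nM to 20000 nM.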

Compound 4, half-maximal inhibitory concentration: 12100 nM
The estimate for compound 4 lay 2.4-fold (0.38 log units) below the measured number, within the range that was stated.
By their numbers in this assay, from the lowest: compounds 1 and 2 (each within the scatter of the next); then compound 4. At a limit, above all of these: compound 3.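

Going by these compounds alone, the change of cap gives a 5.1-fold higher number from compound 1 to compound 4 (0.71 log units; beyond the scatter) in this assay, and this is the first measured step in the set that isolates a single place. It shows that the group on the amide-type nitrogen affects the number even when the chain and its fluorinated end are kept. The change also goes beyond a matter of heavy-atom count: 1,3-benzothiazol-2-yl and 4-acetylphenyl each carry 9 heavy atoms, yet they differ in their rings, with a five-membered aromatic ring with 2 hetero atoms leaving and a double bond outside aromatic rings entering.

This single step swaps the ring system and the acetyl group together, so it leaves open which of them accounts for the change, and a plain phenyl cap, a 4-methoxyphenyl cap or a 4-aminophenyl cap on the same chain would be needed to separate the two. Compound 3 carries a different chain end and stands at a limit of the assay, so it adds no step on this change: the limit of > 100000 nM in this assay, at which 1 of the 4 values shown sits.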